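Para substituent on the benzyl group: compound 4

A few compounds are considered here, and "the series" means these few. Any claim that something is new, unique, unknown or untested is made for them only; others in the source may bear on it.

Measured in a functional assay on HT-29 cells (Homo sapiens) for cytotoxicity, read by MTT assay, with a stated time of 24 h, tested at 80 ug/mL; a lower number here means a weaker effect, a higher number a stronger effect of the compound at the concentration tested:
- compound 1 `CN(C)/C=C/N1CCN(CC(=O)Nc2ccc(-c3nc(-c4ccccc4)c(-c4ccccc4)n3C)cc2)CC1`: 45.4%
- compound 2 `Cn1c(-c2ccc(NC(=O)CN3CCN(Cc4ccccc4)CC3)cc2)nc(-c2ccccc2)c1-c1ccccc1`: 54.5%
- compound 3 `Cc1ccc(CN2CCN(CC(=O)Nc3ccc(-c4nc(-c5ccccc5)c(-c5ccccc5)n4C)cc3)CC2)cc1`: 54.2%

Compound 3 stands second of the three numbers; the two steps that reach it are a number 0.3 percentage points lower from compound 2 to compound 3 (within the scatter) and a number 8.8 percentage points higher from compound 1 to compound 3 (within the scatter), both within the scatter. Compound 4 `Cn1c(-c2ccc(NC(=O)CN3CCN(Cc4ccc(Cl)cc4)CC3)cc2)nc(-c2ccccc2)c1-c1ccccc1` differs from compound 3 by chloro in place of methyl on an aromatic carbon. Among the measured compounds shown here, the steps that bear on it are a number 0.3 percentage points lower from compound 2 to compound 3 (within the scatter), the only change at this aromatic carbon, and a number 9.1 percentage points higher from compound 1 to compound 2 (within the scatter), all within the scatter. For the measured compounds named here, no measured step involves chloro, so there is no basis for expecting a move beyond the scatter. The expected step is a number 0.2 percentage points lower from compound 3 to compound 4 (within the scatter). For compound 4 the estimate in this assay is 54%, with a range from 42% to 66%.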

Compound 4, a percentage reported as activity, at one concentration (the size of the read-out at that concentration, not a potency): 60.7%
Estimate against measurement, compound 4: 6.7 percentage points below; the measured number falls inside the stated range.
By their numbers in this assay, from the lowest: compounds 1, 3, 2 and 4 (each within the scatter of the next, the first and the last beyond it).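

In this assay chloro on this aromatic carbon gives a number 6.5 percentage points higher from compound 3 to compound 4 (within the scatter) and a number 6.2 percentage points higher from compound 2 to compound 4 (within the scatter), so hydrogen, methyl and chloro at this place are not separated. Across the ring nitrogen, 4-chlorobenzyl is the first group to separate from 2-(dimethylamino)ethenyl, with a number 15.3 percentage points higher from compound 1 to compound 4 (beyond the scatter) as the first step in the series beyond the scatter. No measured evidence accounts for this result. Still open, on these data alone, is whether a methoxy group, an amine or a carboxylic acid on this aromatic carbon would leave the scatter, and whether a longer chain in place of the benzyl link would change the reading.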